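Dropping one trifluoromethyl from a diaryl urea

The compounds below may be only part of what the source reports. "The series", "measured", "known", "first", "only" and "open" are said of these compounds alone.

Compound 1 `O=C(Nc1cccc(-n2cc(-c3ccncc3)c(-c3cc(O)cc(Cl)c3)n2)c1)Nc1ccc(Cl)c(C(F)(F)F)c1` gives -77% in a functional assay on COLO 205 cells (Homo sapiens) for inhibition, read by sulforhodamine B assay, with a stated time of 48 h, tested at 100 uM; a lower number here means a stronger effect, a higher number a weaker effect of the compound at the concentration tested.
Compound 2 `O=C(Nc1cccc(-n2cc(-c3ccncc3)c(-c3cc(O)cc(Cl)c3)n2)c1)Nc1ccc(Cl)c(Cl)c1` gives -88% in this assay.
Compound 3 `COc1cc(Cl)cc(-c2nn(-c3cccc(NC(=O)Nc4cc(C(F)(F)F)cc(C(F)(F)F)c4)c3)cc2-c2ccncc2)c1` gives -68% in this assay.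

Compound 3 stands at the highest of the three numbers in this assay. Its nearest neighbour is compound 1, whose value lies within the usual scatter of compound 3; compound 2 lies further off, beyond the scatter. Compound 4 `COc1cc(Cl)cc(-c2nn(-c3cccc(NC(=O)Nc4cccc(C(F)(F)F)c4)c3)cc2-c2ccncc2)c1` has not yet been measured. It differs from compound 3 in one place: hydrogen in place of trifluoromethyl on an aromatic carbon.

Among the measured compounds shown here, only one measured step bears on this change, and only loosely. It is a number 11 percentage points lower from compound 1 to compound 2 (beyond the scatter). That step swaps one substituent for another, whereas the step to compound 4 removes a trifluoromethyl altogether and leaves a hydrogen in its place. The single-trifluoromethyl compounds 1 and 2 both sit lower than the doubly substituted compound 3, but the gap to compound 1 is within the scatter, so no firm direction can be read from them. The expected outcome for compound 4 is a small shift towards a weaker effect, a number 10 percentage points higher from compound 3 to compound 4 (within the scatter), though a result within the scatter would not surprise. Compound 4 is estimated at -58%, with a likely range from -80% to -35%.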

Compound 4, a percentage reported as activity, at one concentration (the size of the read-out at that concentration, not a potency): -95%
Beside the measured number, compound 4's estimate is 37 percentage points above it; the whole stated range lies above it.
By their numbers in this assay, from the lowest: compounds 4 and 2 (each within the scatter of the next); then compounds 1 and 3 (each within the scatter of the next).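

In this assay, the step for hydrogen in place of trifluoromethyl on this aromatic carbon is a number 27 percentage points lower from compound 3 to compound 4 (beyond the scatter), so the trifluoromethyl at this place, meta to a trifluoromethyl group, is not required for the effect at the concentration tested, and the number falls when it leaves. The earlier pair showed only one substituent exchanged for another, in a number 11 percentage points lower from compound 1 to compound 2 (beyond the scatter), whereas here four heavy atoms leave and no heavy atom enters, and the effect still grows stronger rather than weaker. No measurement offered here accounts for this shift.

On these data alone, this rests on a single pair at one concentration, a read-out of size and not of potency, and it is open whether the same step would hold on the hydroxy-bearing core of compound 1 and compound 2. As far as these compounds go, it is also open where a methyl, an amine or a carboxylic acid on this aromatic carbon would fall relative to the hydrogen of compound 4 and the trifluoromethyl of compound 3.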